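A few compounds are considered here, and "the series" means these few. Any claim that something is new, unique, unknown or untested is made for them only; others in the source may bear on it.

Of the compounds shown here, three of a shared core have been tested in an ADME assay on MT4 cells (Homo sapiens) for cytotoxicity, read by MTT assay, with a stated time of 5 days; a lower number here means that less compound is tolerated, a higher number that more compound is tolerated. Compound 1 `Cc1cc(/C=C/C#N)cc(C)c1Oc1nc(Nc2ccc(CN3CCN(S(C)(=O)=O)CC3)cc2)nc2ccsc12` gives 20700 nM. Compound 2 `Cc1cc(/C=C/C#N)cc(C)c1Oc1nc(Nc2ccc(N3CCCC(N)C3)cc2)nc2ccsc12` carries 3-aminopiperidin-1-yl where compound 1 carries (4-(methylsulfonyl)piperazin-1-yl)methyl. In this assay compound 2 gives 3820 nM; this step is a 5.4-fold lower number from compound 1 to compound 2 (0.73 log units; beyond the scatter). Compound 3 `Cc1cc(/C=C/C#N)cc(C)c1Oc1nc(Nc2ccc(CN3CCN(S(C)(=O)=O)CC3)cc2)nc2sccc12` has the same side group as compound 1 on a differently arranged core. In this assay compound 3 gives 131000 nM, the highest of the three numbers, and its nearest neighbour is compound 1.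

The unmeasured compound 4 `Cc1cc(/C=C/C#N)cc(C)c1Oc1nc(Nc2ccc(N3CCCC(NS(N)(=O)=O)C3)cc2)nc2sccc12` keeps the core of compound 3 and differs in one place: 3-(sulfamoylamino)piperidin-1-yl in place of (4-(methylsulfonyl)piperazin-1-yl)methyl on an aromatic carbon. Within the data shown here, the only measured step that bears on this is the one from compound 1 to compound 2, where a ring amine took the place of the same leaving group on the other core. The entering group of compound 4 is a related but not identical piperidine, so a step of comparable size and the same direction is expected in this assay, namely a 4.0-fold lower number from compound 3 to compound 4 (0.60 log units; beyond the scatter). Compound 4 is therefore estimated at 33000 nM, with a likely range from 10000 nM to 100000 nM.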

Compound 4, half-maximal cytotoxic concentration: > 217000 nM
Compound 4 was reported as a limit (the forecaster's own chance of this, stated with the estimate: 10%); middle value at least 6.5-fold (0.81 log units) away from the limit.
By their numbers in this assay, from the lowest: compound 2; then compound 1; then compound 3. At a limit, above all of these: compound 4.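

For compound 4 the reading in this assay is a limit and not a number: (the limit of > 217000 nM in this assay, at which 1 of the 4 values shown sits). On the core of compound 3, replacing the (4-(methylsulfonyl)piperazin-1-yl)methyl group with 3-(sulfamoylamino)piperidin-1-yl gives no lower number (an at least 1.6-fold higher number from compound 3 to compound 4 (0.21 log units; that floor lies within the scatter)). The earlier step on the core of compound 1 went the other way with 3-aminopiperidin-1-yl (a 5.4-fold lower number from compound 1 to compound 2 (0.73 log units; beyond the scatter)), so that drop does not carry over to this group on this core.

As far as these compounds go, it stays open whether the core or the group on the piperidine decides the outcome, as 3-aminopiperidin-1-yl appears only on the core of compound 1 and 3-(sulfamoylamino)piperidin-1-yl only on the core of compound 3. Also open, from the compounds shown here alone, is how a piperidine carrying a carboxylic acid or an acetylamino group at this place would read in this assay.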